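The source may hold more compounds than are shown below. What is called first, only, known or untested is meant among the compounds shown, and "the series" means these compounds.

Measured compounds:
- Compound 1 `COc1cc2c(Oc3ccc(NC(=S)N/N=C/c4ccccc4)cc3F)ccnc2cc1OCCCN1CCCCC1`: in a functional assay on A549 cells (Homo sapiens) for cytotoxicity, read by MTT assay, with a stated time of 72 h (a higher number here means a weaker inhibitor, a lower number a stronger inhibitor), compound 1 gives 330 nM.
- Compound 2 `COc1cc2c(Oc3ccc(NC(=S)N/N=C/c4ccc(F)c(F)c4)cc3F)ccnc2cc1OCCCN1CCCCC1`: in this assay compound 2 gives "not determined" (no result reported).

Compound 1 and compound 2 share the same core and differ only in the ring hanging on the carbon with a double bond to nitrogen. For the measured compounds named here, for compound 1 a concentration value in this assay is available, while for compound 2 no single number is reported, so compound 2 cannot be placed on the scale and no measured step from it to compound 3 exists.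

Compound 3 `COc1cc2c(Oc3ccc(NC(=S)N/N=C/c4ccc(F)cc4Cl)cc3F)ccnc2cc1OCCCN1CCCCC1` is the next member. Relative to compound 2 the change is 2-chloro-4-fluorophenyl in place of 3,4-difluorophenyl on a carbon with a double bond to nitrogen, a swap of one halogen for another within the same ring, with no change in donor or acceptor count. Going by the values given here, with no measured step available, the author expects the change from compound 2 to compound 3 in this assay to stay within the usual scatter, in no particular direction, and takes compound 1 as the nearest anchor.

On that basis compound 3 is expected to give about 400 nM in this assay, with a plausible range from 130 nM to 1300 nM.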

Compound 3, half-maximal inhibitory concentration: 230 nM
Compound 3: middle estimate off by 1.7-fold (0.24 log units), on the high side; the measured number falls inside the stated range.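

In this assay, for the compounds shown here, replacing phenyl with 2-chloro-4-fluorophenyl on a carbon with a double bond to nitrogen gives a 1.4-fold lower number from compound 1 to compound 3 (0.16 log units; within the scatter), the first readable step at this position. In this one pair, a ring carrying a chlorine and a fluorine therefore reads the same as the unsubstituted phenyl ring, so adding these two halogens leaves the cytotoxicity number unmoved. The step between compound 2 and compound 3 cannot be read, which leaves 3,4-difluorophenyl unplaced, and no measurement at hand offers an explanation for the likeness of compound 1 and compound 3.

The compounds shown carry only hydrogen, fluorine or chlorine on this ring, so it remains open whether a methoxy group, a nitrile, a dimethylamino group or a carboxylic acid there would also leave the number in place. A single pair also cannot tell whether the outcome depends on where the halogens sit or on which halogens they are, and a comparison with a 2,4-dichlorophenyl ring would bear on that question.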